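Swapping chloro for hydrogen on compound 1

A few compounds are considered here, and "the series" means these few. Any claim that something is new, unique, unknown or untested is made for them only; others in the source may bear on it.

Among the compounds with values here, in a functional assay on MCF7 cells (Homo sapiens) for cytotoxicity, read by XTT assay, with a stated time of 24 h (a lower number here means a stronger inhibitor, a higher number a weaker inhibitor), compound 1 (`CC(=O)Oc1cc(OC(C)=O)c2c(OC(C)=O)cc(C)c(Cl)c2c1OC(C)=O`) gives 51100 nM and holds the highest of the two numbers so far, which makes it the weaker of the pair, while compound 2 (`COc1c(C)cc(Cl)c2c1C(=O)C=CC2=O`) gives 16200 nM and lies below it by more than the scatter. Compound 3 (`CC(=O)Oc1cc(OC(C)=O)c2c(OC(C)=O)cc(C)cc2c1OC(C)=O`) has hydrogen in place of chloro on an aromatic carbon and is otherwise the same. Within the data shown here, no measured pair shows this change alone, so the expected step in this assay is none beyond the scatter (a 1.1-fold lower number from compound 1 to compound 3 (0.06 log units; within the scatter)). The estimated value for compound 3 is 45000 nM (expected range from 18000 nM to 110000 nM).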

Compound 3, half-maximal inhibitory concentration: 82000 nM
Beside the measured number, compound 3's estimate is 1.8-fold (0.26 log units) below it; the range from low to high includes it.
By their numbers in this assay, from the lowest: compound 2; then compounds 1 and 3 (each within the scatter of the next).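

In this assay, the step for hydrogen in place of chloro on this aromatic carbon is a 1.6-fold higher number from compound 1 to compound 3 (0.21 log units; within the scatter) and so gives no measurable separation between the two compounds. On this core, then, the chloro is not needed to keep the number in this range. No measurement available here bears on the reason for this result.

As far as these compounds go, only chloro and hydrogen are compared at this carbon, so an amine or a bromo group there remains open. From the compounds shown here alone, whether the same swap would read alike on the core of compound 2 also remains open.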